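The source may hold more compounds than are shown below. What is called first, only, known or untested is meant among the compounds shown, and "the series" means these compounds.

Two compounds share one core and differ only in the aromatic group carried on a saturated chain carbon bound to a nitrogen on an aromatic ring. Compound 1 `COc1cccc(CNc2nc(N)c3nc(-c4ccc(C)o4)sc3n2)c1` bears 3-methoxyphenyl there, and in an assay on CHO cells for displacement of a labelled ligand from adenosine receptor A1 (Homo sapiens), read by scintillation counting, with a stated time of 90 min (on this read-out lower numbers stand for stronger inhibition and higher numbers for weaker inhibition), compound 1 gives 70 nM. Compound 2 `Cc1ccc(-c2nc3c(N)nc(NCc4cccs4)nc3s2)o1` bears thiophen-2-yl instead, and in this assay compound 2 gives 71 nM. That exchange produced a 1.0-fold higher number from compound 1 to compound 2 (0.01 log units; within the scatter). Within the data shown here, of the two numbers known, compound 2 has the higher one, with compound 1 its nearest neighbour, but the gap between them is within the scatter, so no order between the two can be claimed.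

Compound 3 `COc1ccccc1CNc1nc(N)c2nc(-c3ccc(C)o3)sc2n1` has not been measured. It differs from compound 2 in one place: 2-methoxyphenyl in place of thiophen-2-yl on a saturated chain carbon bound to a nitrogen on an aromatic ring. Among the measured compounds shown here, the only measured step that bears on this is the exchange of one aromatic group for another at the same place, which left the number essentially unchanged. A methoxyphenyl group returns, 2-methoxyphenyl in place of the 3-methoxyphenyl of compound 1, and nothing measured shows whether that distinction matters. The expected step in this assay is therefore none beyond the scatter, a 1.0-fold lower number from compound 2 to compound 3 (0.01 log units; within the scatter). Compound 3 is estimated at 70 nM in this assay, with a range from 25 nM to 200 nM.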

Compound 3, inhibition constant: 29 nM
Compound 3: the middle estimate sits 2.4-fold (0.38 log units) above what was measured; low and high end bracket the measured number.
By their numbers in this assay, from the lowest: compound 3; then compounds 1 and 2 (each within the scatter of the next).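

Among these compounds, this position responds to the group it carries: in this assay the exchange of thiophen-2-yl for 2-methoxyphenyl gives a 2.4-fold lower number from compound 2 to compound 3 (0.39 log units; beyond the scatter) and is the first change in this short series to go beyond the scatter. The exchange of 3-methoxyphenyl for 2-methoxyphenyl gives a 2.4-fold lower number from compound 1 to compound 3 (0.38 log units; beyond the scatter) and shows that two groups with the same name apart from the ring number are not interchangeable here, even though 3-methoxyphenyl and thiophen-2-yl could not be told apart in the earlier comparison. Nothing available here offers an explanation for the lower number of compound 3.

The three compounds leave open whether the methoxy group itself matters, since a plain phenyl, a 2-chlorophenyl or a 4-methoxyphenyl group at this place would be needed to separate the role of the methoxy group from that of the ring. From the compounds shown here alone, they also carry only aromatic groups on this saturated chain carbon, so it remains unknown how a cyclohexyl ring, a longer chain or an amine would fare.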